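The compounds below may be only part of what the source reports. "The series", "measured", "known", "first", "only" and "open" are said of these compounds alone.

Going by the values given here, in a functional assay on LoVo cells (Homo sapiens) for inhibition, read by MTT assay, with a stated time of 72 h (on this read-out lower numbers stand for stronger inhibition and higher numbers for weaker inhibition), compound 1 (`C=C(Br)C(=O)Nc1cccc(/C=C/C(=O)Nc2ccccc2)c1`) gives 3900 nM, the higher of the two numbers known so far. Compound 2 (`C=C(Br)C(=O)Nc1cccc(/C=C/C(=O)Nc2cccc3ccccc23)c1`) gives 1160 nM, lower by more than the usual scatter. Compound 3 (`C=C(Br)C(=O)Nc1cccc(/C=C/C(=O)Nc2ccc(F)cc2)c1`) differs from compound 1 in one place: fluoro in place of hydrogen on an aromatic carbon. This puts fluoro in place of hydrogen on an aromatic carbon, turning phenyl into 4-fluorophenyl. Among the compounds with values here, no measured pair shows this change, so only a modest shift toward stronger inhibition, within or near the scatter, is expected. The expected change is a 1.3-fold lower number from compound 1 to compound 3 (0.11 log units; within the scatter). The estimate for compound 3 is 3000 nM, with an expected range from 1400 nM to 6500 nM.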

Compound 3, half-maximal inhibitory concentration: 4800 nM
For compound 3 the middle estimate is 1.6-fold (0.20 log units) below the measured one; measured number inside the range.
By their numbers in this assay, from the lowest: compound 2; then compounds 1 and 3 (each within the scatter of the next).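

In this assay, replacing phenyl with 4-fluorophenyl gives a 1.2-fold higher number from compound 1 to compound 3 (0.09 log units; within the scatter), so the two compounds cannot be told apart on this read-out. Going by these compounds alone, this is the first direct test of this position, and it shows that a single fluoro here can be accommodated without a clear difference in inhibition. No measurement at hand explains this result. Fluoro is only one small group, so the compounds shown leave open whether an amine, a carboxylic acid or a longer chain at this position would give a clearly different number from compound 1.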